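Swapping a ring for a short chain

The compounds below may be only part of what the source reports. "The series", "measured", "known", "first", "only" and "open" are said of these compounds alone.

Compound 1 `Cc1c(C)c2c(c(C)c1O)CCC(C)(COc1ccc(/C=C3/SC(=O)NC3=O)cc1)O2` gives 5.31
Compound 2 `O=C1NC(=O)C(Cc2ccc(OCC3CCCCO3)cc2)S1` gives 2.29
Compound 3 `CC(C)COc1ccc(/C=C2\SC(=O)NC2=O)cc1` gives 3.09

All three numbers come from a physicochemical assay for lipophilicity (a higher number here means a more lipophilic compound, a lower number a more polar compound), as the measure. Compound 2 stands lowest of the three. Compound 3 is its nearest neighbour and lies higher by more than the usual scatter of repeated measurements, while compound 1 lies furthest away, also beyond that scatter.

The next compound, compound 4 `CCCOc1ccc(CC2SC(=O)NC2=O)cc1`, has not been measured yet. It differs from compound 2 in one place: ethyl in place of oxan-2-yl on a saturated chain carbon bound to an oxygen on an aromatic ring. Put more shortly, compound 4 carries a propyl group where compound 2 carries (oxan-2-yl)methyl.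

Within the data shown here, no measured pair shows this change alone, so any forecast is a judgement. Compound 3 also lacks the oxan-2-yl group and gives 3.09 in this comparison, although it differs from compound 4 elsewhere too. Compound 1 warns against a simple rule, since its side group holds a ring and it gives 5.31 on the same scale. An upward step of a number 0.41 log units higher from compound 2 to compound 4 (beyond the scatter) is expected, slightly beyond the scatter. In this assay compound 4 is estimated at 2.7 with an expected range of 2.3 to 3.1 as the likely span.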

Compound 4, partition coefficient: 2.96
Compound 4: middle estimate off by 0.26 log units, on the low side; low and high end bracket the measured number.
By their numbers in this assay, from the lowest: compound 2; then compounds 4 and 3 (each within the scatter of the next); then compound 1.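

In this assay, among these compounds, this pair gives the first direct reading of a single change on a saturated chain carbon bound to an oxygen on an aromatic ring: ethyl in place of oxan-2-yl gives a step of a number 0.67 log units higher from compound 2 to compound 4 (beyond the scatter) in this series. The earlier compounds shown here could not show this, as none of them differed from another in one place only. The group that leaves has 6 heavy atoms, one six-membered non-aromatic ring and 1 hydrogen-bond acceptor, while the group that enters has 2 heavy atoms, no ring and no acceptor, so here the smaller group stands with the higher number, although this single pair sets no general rule. No measurement shown here explains the direction or size of this step.

Going by these compounds, what remains open is whether the ring or its oxygen matters more for this step, and a cyclohexylmethyl group in the same place would separate the two. A longer chain such as pentyl in place of propyl would show whether the number keeps moving in the same direction as the chain grows.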